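Swapping the Aromatic Ring on a Hydroxy-Bearing Phenyl

The source may hold more compounds than are shown below. What is called first, only, known or untested is meant among the compounds shown, and "the series" means these compounds.

Of the compounds shown here, two sharing one core have been measured in an assay on isolated protein for inhibition of 2-Hydroxyacid oxidase 1 (Homo sapiens), with stated times of 30 min and 15 min; a lower number here means a stronger inhibitor, a higher number a weaker inhibitor. Compound 1 `Cc1csc(-c2cccc(CN(C)c3ccc4[nH]nc(C(=O)O)c4c3)c2)n1` gives 650 nM. Compound 2 `CN(C)c1noc(-c2cccc(CN(C)c3ccc4[nH]nc(C(=O)O)c4c3)c2O)n1` gives 21 nM and so stands lowest of the two numbers, well beyond the scatter from compound 1. These two compounds differ in more than one place, so their values alone do not separate the parts of that gap.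

Among the compounds with values here, compound 3 `CC(C)c1csc(-c2cccc(CN(C)c3ccc4[nH]nc(C(=O)O)c4c3)c2O)n1` differs from compound 2 in a single place: 4-isopropyl-1,3-thiazol-2-yl in place of 3-(dimethylamino)-1,2,4-oxadiazol-5-yl on an aromatic carbon With no measured pair that isolates this exchange, there is no step to lean on. The expected outcome is a moderate weakening, a 3.8-fold higher number from compound 2 to compound 3 (0.58 log units; beyond the scatter), beyond the scatter but staying far from compound 1. Compound 3 is therefore estimated to give 80 nM in this assay, with a range of 20 nM to 320 nM.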

Compound 3, half-maximal inhibitory concentration: 35 nM
The estimate for compound 3 lay 2.3-fold (0.36 log units) above the measured number; measured number inside the range.
By their numbers in this assay, from the lowest: compounds 2 and 3 (each within the scatter of the next); then compound 1.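

In this assay, placing 4-isopropyl-1,3-thiazol-2-yl instead of 3-(dimethylamino)-1,2,4-oxadiazol-5-yl on this aromatic carbon, ortho to a hydroxy group, gives a 1.7-fold higher number from compound 2 to compound 3 (0.22 log units; within the scatter). This position therefore tolerates both five-membered aromatic rings without a change beyond the scatter, although they differ in their hetero atoms and hydrogen-bond acceptors. No measurement shown here explains why the two exchanged groups read alike.

Going by these compounds, the share of the hydroxy group in the gap to compound 1 stays open, since compound 1 differs from compound 3 in two places: it lacks that hydroxy group and has a methyl group on its ring where compound 3 has isopropyl. Also open, on these data alone, is how a methoxy group in place of the hydroxy group, or an amine on the five-membered ring, would read.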